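Removing a chloro from the core of compound 2

The source may hold more compounds than are shown below. What is called first, only, known or untested is meant among the compounds shown, and "the series" means these compounds.

Measured so far:
Compound 1, `ClCc1ccccc1Cn1cnc2c(Cl)nc(Cl)nc21`: 1730 nM
Compound 2, `ClCc1ccc(Cn2cnc3nc(Cl)nc(Cl)c32)cc1`: 670 nM
Compound 3, `ClCc1ccccc1Cn1cnc2nc(Cl)nc(Cl)c21`: 4260 nM

In a functional assay on NCI-H322M cells (Homo sapiens) for cytotoxicity, read by sulforhodamine B assay, with a stated time of 48 h (a lower number here means a stronger inhibitor of growth, a higher number a weaker inhibitor of growth), compound 2 gives 670 nM, the lowest of the three numbers. Its gaps to compound 1 and to compound 3 both lie beyond the usual scatter, so among these three compound 2 is the strongest inhibitor of growth, with compound 3 the weakest.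

The untested compound 4, `ClCc1ccc(Cn2cnc3ncnc(Cl)c32)cc1`, differs from compound 2 in one place: hydrogen in place of chloro on an aromatic carbon. For the measured compounds named here, no pair of measured compounds shows this particular change, so there is no measured step to lean on; the three measured compounds differ among themselves in the placement of the chloromethyl group and in the orientation of the core, not in the number of chloro groups on the core.

With nothing to guide it, the step from compound 2 to compound 4 is expected to be a modest loss, roughly a 2.2-fold higher number from compound 2 to compound 4 (0.35 log units; beyond the scatter), with a wide range. Compound 4 is therefore estimated at 1500 nM, between 500 nM and 5000 nM.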

Compound 4, concentration for 50% growth inhibition: 1620 nM
Compound 4: middle estimate off by 1.1-fold (0.03 log units), on the low side; the measured number falls inside the stated range.
By their numbers in this assay, from the lowest: compound 2; then compounds 4 and 1 (each within the scatter of the next); then compound 3.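

In this assay the chloro on the aromatic carbon between two ring nitrogen atoms turns out to matter: hydrogen in its place gives a 2.4-fold higher number from compound 2 to compound 4 (0.38 log units; beyond the scatter) and this step lies beyond the scatter. For the compounds shown here, this is the first measured change in the number of chloro groups on the core, and it shows that this chloro contributes to the growth inhibition of compound 2, though compound 4 remains a measurable inhibitor without it. Nothing measured here accounts for this loss.

On these data alone, whether an amine, a methoxy group or a methyl group on this carbon would match chloro remains open. So does whether the same change would cost as much with the chloromethyl group placed as in compound 1, or with the core oriented as in compound 3.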